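Silyl ether on the hydroxy-bearing cyclopentenone series

The compounds below may be only part of what the source reports. "The series", "measured", "known", "first", "only" and "open" are said of these compounds alone.

Measured in an ADME assay on HEK293 cells (Homo sapiens) for cytotoxicity, read by MTT assay, with a stated time of 72 h; on this read-out lower numbers stand for stronger inhibition and higher numbers for weaker inhibition:
Compound 1, `COc1ccc(C2=C(c3cc(OC)c(OC)c(OC)c3)C(=O)CC2O[SiH2]C(C)(C)C)cc1OC`, gives > 100 ug/mL, a limit of the assay.
Compound 2, `COc1ccc(C2=C(c3cc(OC)c(OC)c(OC)c3)C(=O)CC2O)cc1`, gives 10 ug/mL.
Compound 3, `COc1ccc(C2=C(c3cc(OC)c(OC)c(OC)c3)C(=O)CC2O)cc1O`, gives > 100 ug/mL, again a limit of the assay.

Compound 3 thus stands at the limit of > 100 ug/mL in this assay, at which 2 of the 3 values shown sit, with only a bound and no number. For the measured compounds named here, the one measured step, an at least 10-fold higher number from compound 2 to compound 3 (1.00 log units; beyond the scatter), concerns the hydroxy group and not the change now in hand. Compound 4, `COc1ccc(C2=C(c3cc(OC)c(OC)c(OC)c3)C(=O)CC2O[SiH2]C(C)(C)C)cc1O`, differs from compound 3 by a group of 5 heavy atoms (4 carbon, 1 silicon; no ring) in place of a hydrogen atom, on an oxygen on a saturated carbon. Going by the values given here, no measured step bears directly on this change; compound 1 shows only that a compound carrying the same silicon group also reached the limit. The estimate for compound 4 is therefore a step that the limit leaves unreadable from compound 3 to compound 4 within the scatter, with compound 4 expected at 150 ug/mL (range 60 ug/mL to 400 ug/mL), most likely reported again as a limit.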

Compound 4, half-maximal inhibitory concentration: 42 ug/mL
For compound 4 the middle estimate is 3.6-fold (0.55 log units) above the measured one; measured number below the stated range.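

In this assay, the group of 5 heavy atoms (4 carbon, 1 silicon; no ring) on an oxygen on a saturated carbon gives an at least 2.3-fold lower number from compound 3 to compound 4 (0.37 log units; beyond the scatter), so placing this group on that oxygen does not keep the number at the limit. Compound 1 carries the same group, and hydrogen in place of methyl on an oxygen on an aromatic ring gives an at least 2.3-fold lower number from compound 1 to compound 4 (0.37 log units; beyond the scatter), so the silicon group alone does not set the read-out.

As far as these compounds go, both steps start from a limit, and their full size stays open: the limit of > 100 ug/mL in this assay, at which 2 of the 4 values shown sit. Also open, from the compounds shown here alone, is whether an acetyl ester or an amine at this place would lower the number as the silicon group does.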